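A few compounds are considered here, and "the series" means these few. Any claim that something is new, unique, unknown or untested is made for them only; others in the source may bear on it.

Measured so far:
compound 1 `O=S(=O)(Nc1cccc(CO)c1)c1ccc(-c2ccc(Br)cc2)cc1` — 2500 nM
compound 2 `CN(C)c1ccc(-c2ccc(S(=O)(=O)Nc3cccc(CO)c3)cc2)cc1` — > 5000 nM, which is a limit of the assay and not a number

Going by the values given here, in a functional assay on J774 cells (Mus musculus) for cytotoxicity, read by resazurin assay, with a stated time of 72 h (on this read-out lower numbers stand for stronger inhibition and higher numbers for weaker inhibition), compound 1 stands as the only compound with a true number; the remaining entry is a limit. Among the compounds with values here, the single measured step, an at least 2.0-fold higher number from compound 1 to compound 2 (0.30 log units; that floor lies within the scatter), arises from dimethylamino in place of bromo on an aromatic carbon of the outer ring, and its size can only be given as a floor because compound 2 sits at the limit of > 5000 nM in this assay, at which 1 of the 2 values shown sits.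

Compound 3 `COc1ccc(CO)cc1NS(=O)(=O)c1ccc(-c2ccc(Br)cc2)cc1` differs from compound 1 in another part of the molecule: methoxy in place of hydrogen on an aromatic carbon. Within the data shown here, the one measured step concerns a different ring and a different kind of group, so no measured step bears directly on this change. With nothing to point either way, the expectation is for no step beyond the scatter, a 1.2-fold higher number from compound 1 to compound 3 (0.08 log units; within the scatter), so that compound 3 is expected to stay close to compound 1. The estimate for compound 3 in this assay is 3000 nM, with a range from 1000 nM to 10000 nM, and a real chance that only a limit is reported.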

Compound 3, half-maximal inhibitory concentration: 2500 nM
Compound 3: middle estimate off by 1.2-fold (0.08 log units), on the high side, and the stated range covers the measured number.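

In this assay, going by these compounds alone, methoxy in place of hydrogen on an aromatic carbon, ortho to a large group and para to a hydroxymethyl group, gives no change at the digits printed from compound 1 to compound 3 (within the scatter), and this is the first measured step at this position rather than on the outer ring. Unlike the only earlier step, it rests on a true number at both ends, so its size can be read directly and not merely as a floor. For this one change, then, the added methoxy leaves the read-out where it stood, but no measurement shown says why the number holds at this position.

What the compounds shown leave open is whether this holds only for methoxy or also for other groups at the same place, such as a hydroxyl, an amine, a carboxylic acid or a longer chain like butoxy. They also leave open whether methoxy at this position would give the same result with dimethylamino rather than bromo on the outer ring, and whether other positions on the ring that carries the hydroxymethyl group would respond in the same way.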